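Swapping the hydroxymethyl side chain for isopropyl

This account rests on a few compounds, and the source may have more. Where it says the series, first, only, none or still open, it means among the compounds named here.

Measured compounds:
compound 1, `O=C(N[C@@H](CO)C(=O)NO)c1ccc(C#Cc2ccccc2)cc1`, 2
compound 2, `O=C(C[C@H](NC(=O)c1ccc(C#Cc2ccccc2)cc1)C(=O)NO)NCCCO`, 2
compound 3, `CS(=O)(=O)C[C@H](NC(=O)c1ccc(C#Cc2ccccc2)cc1)C(=O)NO`, 2

In a physicochemical assay for lipophilicity (a higher number here means a more lipophilic compound, a lower number a more polar compound), compound 1 stands level with compounds 2 and 3. The step of no change at the digits printed from compound 1 to compound 2 (within the scatter) and the step of no change at the digits printed from compound 1 to compound 3 (within the scatter) both stay within the scatter, as does the step of no change at the digits printed from compound 2 to compound 3 (within the scatter), even though each replaces the hydroxy on a saturated chain carbon with a quite different group.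

Compound 4, `CC(C)C(NC(=O)c1ccc(C#Cc2ccccc2)cc1)C(=O)NO`, has not yet been measured in this assay. It differs from compound 1 thus: a group of 8 heavy atoms (5 carbon, 1 nitrogen, 2 oxygen; no ring) in place of a group of 7 heavy atoms (3 carbon, 1 nitrogen, 3 oxygen; no ring), on an amide-type nitrogen. The steps from compound 1 to compounds 2 and 3 are the closest guide, and they show no change beyond the scatter; however, they exchange one substituent for another at the same chain position, whereas in compound 4 the hydroxy on a saturated chain carbon is gone without any oxygen-bearing group taking its place. A modest rise is therefore expected, with a step of a number 0.60 log units higher from compound 1 to compound 4 (beyond the scatter) from compound 1 to compound 4. Compound 4 is estimated at 2.6, within 2 to 3.3.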

Compound 4, distribution coefficient: > 3
Compound 4: a limit, no number; the forecaster's own chance of this, stated with the estimate: 5%; at least 0.40 log units between middle value and limit.
By their numbers in this assay, from the lowest: compounds 1, 2 and 3 (each within the scatter of the next). At a limit, above all of these: compound 4.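

In this assay compound 4 gives > 3, which is a limit of the assay and not a number. The earlier compounds shown here could suggest that this side chain hardly matters, since hydroxy, (3-hydroxypropyl)carbamoyl and methylsulfonyl all read level, but the isopropyl side chain of compound 4, which carries no oxygen, gives a number at least 1.00 log units higher from compound 1 to compound 4 (beyond the scatter). How far that step really reaches stays unknown, and all that bounds it is this: the limit of > 3 in this assay, at which 1 of the 4 values shown sits.

Three oxygen-bearing side chains and a single one without oxygen cannot show whether the missing oxygen alone accounts for the step. On these data alone, how a longer hydrocarbon chain, an amine or a carboxylic acid at this place would read remains open, as does the actual number for compound 4.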